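A few compounds are considered here, and "the series" means these few. Any claim that something is new, unique, unknown or untested is made for them only; others in the source may bear on it.

Compound 1 `Cc1nn(-c2nc(-c3ccc(Cl)c(Cl)c3)c(SC(C)C)s2)c(C(=O)O)c1-c1cc(C#N)cc(C(F)(F)F)c1` is the starting point. In a functional assay on BJAB cells (Homo sapiens) for antiproliferative activity, with a stated time of 4 days (a higher number here means that more compound is needed for the effect, a lower number that less compound is needed), compound 1 gives 3600 nM, the highest of the two numbers in this set. For the measured compounds named here, compound 3 `Cc1nn(-c2nc(-c3ccc(Cl)c(Cl)c3)c(SC(C)C)s2)c(C(=O)O)c1-c1cc(C(F)(F)F)cc(C(F)(F)F)c1` gives 1800 nM, and the step of a 2.0-fold lower number from compound 1 to compound 3 (0.30 log units; within the scatter) is the only measured step that differs in one place. Compound 2 `Cc1c(-c2cc(Cl)cc(Cl)c2)c(C(=O)O)nn1-c1nc(-c2ccncc2)c(SC(C)C)s1` gives "not active" (no number reported), reported without a number. Compound 4 `CNc1cc(-c2c(C)nn(-c3nc(-c4ccc(Cl)c(Cl)c4)c(SC(C)C)s3)c2C(=O)O)ccn1` differs from compound 1 by 2-(methylamino)pyridin-4-yl in place of 3-cyano-5-(trifluoromethyl)phenyl on an aromatic carbon. Going by the values given here, no measured step bears on this change, since the one step known concerns trifluoromethyl in place of cyano and stays within the scatter. Compound 4 is therefore expected near compound 1, with wide uncertainty, as a step of a 1.4-fold higher number from compound 1 to compound 4 (0.14 log units; within the scatter). The estimate for compound 4 is 5000 nM, ranging from 1000 nM to 30000 nM.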

Compound 4, half-maximal effective concentration: 18000 nM
Beside the measured number, compound 4's estimate is 3.6-fold (0.56 log units) below it; the measured number falls inside the stated range.
By their numbers in this assay, from the lowest: compounds 3 and 1 (each within the scatter of the next); then compound 4.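

In this assay, 2-(methylamino)pyridin-4-yl in place of 3-cyano-5-(trifluoromethyl)phenyl gives a 5.0-fold higher number from compound 1 to compound 4 (0.70 log units; beyond the scatter), so the whole aryl group on this aromatic carbon can move the number beyond the scatter, which the swap of cyano for trifluoromethyl did not show. A ring with a hetero atom here still gives a number. Nothing measured here accounts for the rise. The compounds shown leave the ring nitrogen and the methylamino group unseparated. As far as these compounds go, how a plain pyridin-4-yl or a 2-aminopyridin-4-yl would compare remains open.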